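Chain extension on the bromophenyl member of the series

A few compounds are considered here, and "the series" means these few. Any claim that something is new, unique, unknown or untested is made for them only; others in the source may bear on it.

- compound 1 `COc1cc2c(Nc3ccc(F)c(Cl)c3)ncnc2cc1OCCCn1ccnc1[N+](=O)[O-]`: 2060 nM
- compound 2 `C#Cc1cccc(Nc2ncnc3cc(OCCCCn4ccnc4[N+](=O)[O-])c(OC)cc23)c1`: 590 nM
- compound 3 `COc1cc2c(Nc3cccc(Br)c3)ncnc2cc1OCCCn1ccnc1[N+](=O)[O-]`: 2820 nM

In a functional assay on HT-29 cells (Homo sapiens) for inhibition, read by sulforhodamine B assay, with a stated time of 72 h (a higher number here means a weaker inhibitor, a lower number a stronger inhibitor), compound 3 gives 2820 nM, which places it at the upper end of the three values, within the scatter of compound 1. Compound 2 gives 590 nM, a lower number.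

Compound 4 `COc1cc2c(Nc3cccc(Br)c3)ncnc2cc1OCCCCn1ccnc1[N+](=O)[O-]` keeps the rest of compound 3 and changes only the chain: (2-nitro-1H-imidazol-1-yl)methyl in place of 2-nitro-1H-imidazol-1-yl on a saturated chain carbon, three bonds along the chain from an oxygen on an aromatic ring. In words, (2-nitro-1H-imidazol-1-yl)methyl stands in place of 2-nitro-1H-imidazol-1-yl on a saturated chain carbon, three bonds along the chain from an oxygen on an aromatic ring.

Going by the values given here, no measured step isolates this change. Among the compounds with values here, the single available step, a 1.4-fold higher number from compound 1 to compound 3 (0.14 log units; within the scatter), replaces the group on the nitrogen and leaves the chain untouched, and it stays within the scatter. Within the data shown here, only one measured compound shares the chain of compound 4, and its group on the nitrogen differs as well: compound 2 stands at 590 nM. A move to a lower number is therefore expected, smaller than the gap between the values of compound 2 and compound 3, on thin evidence.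

The expected change is a 2.2-fold lower number from compound 3 to compound 4 (0.34 log units; beyond the scatter) in this assay.

The estimated value for compound 4 is 1300 nM, with an expected range of 550 nM to 2900 nM.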

Compound 4, half-maximal inhibitory concentration: 1430 nM
Compound 4: middle estimate off by 1.1-fold (0.04 log units), on the low side; low and high end bracket the measured number.
By their numbers in this assay, from the lowest: compound 2; then compounds 4, 1 and 3 (each within the scatter of the next).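

In this assay, the chain change now has a direct reading: a 2.0-fold lower number from compound 3 to compound 4 (0.29 log units; within the scatter). At this place, three bonds along the chain from an oxygen on an aromatic ring, (2-nitro-1H-imidazol-1-yl)methyl in place of 2-nitro-1H-imidazol-1-yl therefore cannot be told apart from no change on the bromo member, although the step lies close to the edge of the scatter. Going by these compounds alone, with the chain held constant, the other new step gives the first direct reading of the aromatic group on this chain, a 2.4-fold higher number from compound 2 to compound 4 (0.38 log units; beyond the scatter), beyond the scatter but modest, and no evidence is available to explain either step.

The compounds shown give no reading of the same chain change on the ethynyl or 3-chloro-4-fluorophenyl members, so whether the step seen here carries over to them remains open, as does whether bromo and ethynyl differ on the shorter chain. Also open, going by these compounds, is how a longer chain, or an amine in place of the 2-nitro-1H-imidazol-1-yl, would read in this assay.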